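Cyclohexyl in place of pyridin-4-yl on the amide carbonyl

The compounds below may be only part of what the source reports. "The series", "measured", "known", "first", "only" and "open" are said of these compounds alone.

Measured compounds:
compound 1, `O=C(Nc1nc2ccccc2[nH]1)c1ccncc1`, giving 49000 nM in an assay on BV-2 cells for positive allosteric modulation of metabotropic glutamate receptor 5 (Mus musculus), read by Griess assay, with stated times of 1 h and 24 h; a higher number here means a weaker inhibitor, a lower number a stronger inhibitor
compound 2, `COc1cc(C(=O)Nc2nc3ccccc3[nH]2)ccc1S(N)(=O)=O`, giving 150000 nM in this assay

Compound 1 holds the lower of the two numbers in this assay; compound 2 stands at a number that is higher by more than the usual scatter. Compound 3, `O=C(Nc1nc2ccccc2[nH]1)C1CCCCC1`, has not yet been measured. It differs from compound 1 in one place: cyclohexyl in place of pyridin-4-yl on a carbonyl carbon. Going by the values given here, no measured pair isolates a change of this kind, so the two measured compounds offer no direct guide to its size or direction. The expectation rests on compound 1 alone, whose value of 49000 nM serves as the anchor. The step is estimated to stay within the scatter, with no preferred direction: a 1.2-fold higher number from compound 1 to compound 3 (0.09 log units; within the scatter). Compound 3 is expected to give about 60000 nM in this assay, most likely between 20000 nM and 200000 nM.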

Compound 3, half-maximal inhibitory concentration: 42000 nM
Compound 3: middle estimate off by 1.4-fold (0.15 log units), on the high side, within the range that was stated.
By their numbers in this assay, from the lowest: compounds 3 and 1 (each within the scatter of the next); then compound 2.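

In this assay, going by these compounds alone, cyclohexyl in place of pyridin-4-yl on the carbonyl carbon gives a 1.2-fold lower number from compound 1 to compound 3 (0.07 log units; within the scatter), the first step at this position that can be read from a single change. The aromatic ring with its hetero atom and hydrogen-bond acceptor leaves, a non-aromatic ring of carbon only enters, and the number stays within the scatter, so neither the ring nitrogen nor aromaticity is needed here to hold this level of inhibition. No measurement bears on why the two groups match. Still open, from the compounds shown here alone, is whether any group at this position can move the number beyond the scatter, for example a phenyl, a methyl or a longer alkyl chain. A carboxylic acid or an amine on the cyclohexyl ring would test the same question.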